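Swapping Carbonyl and Ethenyl Order in Compound 4

The source may hold more compounds than are shown below. What is called first, only, known or untested is meant among the compounds shown, and "the series" means these compounds.

Compound 2 `COc1ccc(-c2cc(C(=O)/C=C/c3ccc(Cl)cc3)nc3cc(-c4ccccc4)nn23)cc1OC` stands second highest of the three numbers in a functional assay on A549 cells (Homo sapiens) for antiproliferative activity, read by MTT assay, with a stated time of 24 h (on this read-out higher numbers stand for weaker inhibition and lower numbers for stronger inhibition), where compound 2 gives 22000 nM. Compound 1 `COc1cc(-c2cc(C(=O)/C=C/c3ccc(Cl)cc3)nc3cc(-c4ccccc4)nn23)cc(OC)c1OC` gives 23800 nM and compound 3 `COc1ccc(-c2cc(C(=O)/C=C/c3cc(OC)c(OC)c(OC)c3)nc3cc(-c4ccccc4)nn23)cc1OC` gives 15400 nM, and both steps, a 1.1-fold lower number from compound 1 to compound 2 (0.03 log units; within the scatter) and a 1.4-fold lower number from compound 2 to compound 3 (0.15 log units; within the scatter), stay inside the scatter. Compound 4 `COc1ccc(-c2cc(/C=C/C(=O)c3ccc(Cl)cc3)nc3cc(-c4ccccc4)nn23)cc1OC` carries 2-((4-chlorophenyl)carbonyl)ethenyl in place of (2-(4-chlorophenyl)ethenyl)carbonyl on an aromatic carbon. Within the data shown here, no measured step touches this rearrangement of the same atoms; the two known steps, hydrogen for methoxy and 3,4,5-trimethoxyphenyl for 4-chlorophenyl, each stayed within the scatter, so nothing in these three compounds points to a shift beyond it. Compound 4 is therefore expected at 22000 nM in this assay, between 9000 nM and 55000 nM, an expected step of no change at the digits printed from compound 2 to compound 4 (within the scatter).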

Compound 4, half-maximal inhibitory concentration: 15400 nM
Beside the measured number, compound 4's estimate is 1.4-fold (0.15 log units) above it, within the range that was stated.
By their numbers in this assay, from the lowest: compounds 3, 4, 2 and 1 (each within the scatter of the next).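

In this assay, joining the same atoms in the other order, as 2-((4-chlorophenyl)carbonyl)ethenyl in place of (2-(4-chlorophenyl)ethenyl)carbonyl, gives a 1.4-fold lower number from compound 2 to compound 4 (0.15 log units; within the scatter). Among these compounds, this is the first reading at this aromatic carbon next to the ring nitrogen, and swapping the carbonyl and ethenyl order there produced no shift beyond the scatter. Nothing available explains this reading. The compounds shown leave open whether a different group on this carbon, such as an amine or a carboxylic acid, would move the number beyond the scatter.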